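This account rests on a few compounds, and the source may have more. Where it says the series, first, only, none or still open, it means among the compounds named here.

Working notes on the series. Compound 1 `O=c1[nH]c2ccccc2cc1/C=N/O` gives in a functional assay, read by spectrophotometry, with a stated time of 5 min (a higher number here means a weaker inhibitor, a lower number a stronger inhibitor), a value of 463000 nM. Compound 2 `Cc1ccc2[nH]c(=O)c(/C=N/O)cc2c1` gives in this assay a value of 389000 nM. Compound 3 `Cc1ccc2[nH]c(=O)c(/C=N/Nc3ccccc3)cc2c1` gives in this assay a value of 309000 nM. The change from compound 2 to compound 1 is hydrogen in place of methyl on an aromatic carbon and its step is a 1.2-fold higher number from compound 2 to compound 1 (0.08 log units; within the scatter). The cores of compound 2 and compound 3 differ by anilino in place of hydroxy on a double-bonded nitrogen, a step of a 1.3-fold lower number from compound 2 to compound 3 (0.10 log units; within the scatter). Compound 4 `O=c1[nH]c2ccccc2cc1/C=N/Nc1ccccc1` is not yet measured; it differs from compound 3 by hydrogen in place of methyl on an aromatic carbon, the same change at the same place as between compound 2 and compound 1. Within the data shown here, the expected step from compound 3 to compound 4 is a 1.2-fold higher number from compound 3 to compound 4 (0.07 log units; within the scatter), resting on the single earlier step of a 1.2-fold higher number from compound 2 to compound 1 (0.08 log units; within the scatter). Compound 4 is therefore estimated at 360000 nM, with an expected range from 200000 nM to 650000 nM.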

Compound 4, half-maximal inhibitory concentration: 306000 nM
Estimate against measurement, compound 4: 1.2-fold (0.07 log units) above; the range from low to high includes it.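

Hydrogen in place of methyl on an aromatic carbon gives in this assay a 1.0-fold lower number from compound 3 to compound 4 (0.00 log units; within the scatter), and the two instances of this change agree: the same change on two cores in this assay, a 1.2-fold higher number (0.08 log units; within the scatter) from compound 2 to compound 1 and a 1.0-fold lower number (0.00 log units; within the scatter) from compound 3 to compound 4, 1.2-fold (0.08 log units) apart, within the scatter of two such steps. The change therefore carries between the core with hydroxy and the core with anilino on the double-bonded nitrogen without a readable difference in either case. Among these compounds, this rests on only two pairs, both with steps within the scatter, so it shows no measurable contribution from the methyl on these two cores, not that a step of real size would carry over or that other cores would behave alike.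

On these data alone, it remains open whether a longer chain or a chlorine atom at this place would move the number beyond the scatter. The same holds for an amine or a carboxylic acid on the anilino ring.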